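A few compounds are considered here, and "the series" means these few. Any claim that something is new, unique, unknown or untested is made for them only; others in the source may bear on it.

A small set of compounds was tested in a functional assay on cardiac atrium (Cavia porcellus); on this read-out lower numbers stand for an effect already at smaller amounts and higher numbers for an effect only at larger amounts of compound. For the measured compounds named here, compound 1 `COC(=O)C1=C(C)NC(C)=C(C(=O)OC)C1c1c(-c2cccnc2)nc2sc(C)cn12` gives 12500 nM in this assay, the highest of the two numbers known so far. Going by the values given here, the only other measured compound, compound 2 `COC(=O)C1=C(C)NC(C)=C(C(=O)OC)C1c1c(-c2cccs2)nc2sccn12`, gives 1300 nM, a lower value, and the gap between the two lies beyond the scatter, so compound 1 stands as the weaker of the pair in this assay.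

Compound 3 `COC(=O)C1=C(C)NC(C)=C(C(=O)OC)C1c1c(-c2ccccn2)nc2sc(C)cn12` has not yet been measured. It differs from compound 1 in a single place:

pyridin-2-yl in place of pyridin-3-yl on an aromatic carbon

The two compounds are built from the same atoms, joined differently. Among the compounds with values here, no pair of measured compounds shows a change of this kind, so there is no direct guide to how it plays out in this assay. Without such a guide, the step is expected to be small, with no clear direction, and most likely within the scatter: a 1.3-fold lower number from compound 1 to compound 3 (0.10 log units; within the scatter). Compound 3 is therefore estimated to give 10000 nM in this assay, with an expected range from 3000 nM to 35000 nM.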

Compound 3, half-maximal effective concentration: 39900 nM
Compound 3: middle estimate off by 4.0-fold (0.60 log units), on the low side, outside the stated range (above it).
By their numbers in this assay, from the lowest: compound 2; then compound 1; then compound 3.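

At this aromatic carbon of the five-membered aromatic ring, next to the ring nitrogen, the result shows that this assay is sensitive to how the attached six-membered ring is joined: pyridin-2-yl in place of pyridin-3-yl gives a 3.2-fold higher number from compound 1 to compound 3 (0.50 log units; beyond the scatter), a modest step, but one beyond the scatter. The two groups have the same heavy atoms, the same single hydrogen-bond acceptor and no net charge, so a change in connectivity alone, with no change in these counts, is enough to move the number at this position. Nothing available explains this difference between the two isomers, so the step stands as an observation without a known cause.

The compounds shown leave open how pyridin-4-yl, or a plain phenyl ring with no ring nitrogen, would read at this same carbon, and so whether pyridin-3-yl or pyridin-2-yl lies nearer the usual level for this place. They also leave open whether the step from pyridin-3-yl to pyridin-2-yl would keep its direction and size on a core without the methyl group carried by compound 1 and compound 3.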